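Aryl pyrazole acylthioureas: fluoro to methyl on the pyrazole aryl

This account rests on a few compounds, and the source may have more. Where it says the series, first, only, none or still open, it means among the compounds named here.

Measured so far:
- compound 1, `Cc1ccc(-c2nn(-c3ccccc3)cc2C(=O)NC(=S)Nc2ccc(Cl)cc2)cc1`: 6210 nM
- compound 2, `Cc1ccc(NC(=S)NC(=O)c2cn(-c3ccccc3)nc2-c2ccc(C)cc2)cc1`: 5660 nM
- compound 3, `O=C(NC(=S)Nc1ccc(F)cc1)c1cn(-c2ccccc2)nc1-c1ccc(F)cc1`: 5610 nM

All three compounds share one core and differ only in the substituents on the two outer aromatic rings. In a functional assay on MCF7 cells (Homo sapiens) for inhibition, read by CCK-8 assay, with a stated time of 48 h (a lower number here means a stronger inhibitor, a higher number a weaker inhibitor), compound 3 gives the lowest of the three numbers, but its gap to compound 2 and to compound 1 falls within the scatter, so no order among the three can be read from these values.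

The next compound, compound 4, `Cc1ccc(-c2nn(-c3ccccc3)cc2C(=O)NC(=S)Nc2ccc(F)cc2)cc1`, is reached from compound 3 by methyl in place of fluoro on an aromatic carbon, the aromatic ring in question being the one that carries the pyrazole; the 4-fluorophenyl there becomes a 4-methylphenyl.

Among the measured compounds shown here, only one measured step bears on a halogen-to-methyl exchange on an outer ring: a 1.1-fold lower number from compound 1 to compound 2 (0.04 log units; within the scatter). That exchange sat on the other outer ring, yet it left the number essentially unchanged. Compound 2 and compound 3 likewise sit together despite differing at both rings. On this basis no step beyond the scatter is expected in this assay for the change to compound 4.

Compound 4 is therefore estimated at 5700 nM, with a range of 3000 nM to 11000 nM, meaning an expected step of a 1.0-fold higher number from compound 3 to compound 4 (0.01 log units; within the scatter).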

Compound 4, half-maximal inhibitory concentration: 6420 nM
The estimate for compound 4 lay 1.1-fold (0.05 log units) below the measured number; the measured number falls inside the stated range.
By their numbers in this assay, from the lowest: compounds 3, 2, 1 and 4 (each within the scatter of the next).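

In this assay, the exchange of 4-fluorophenyl to 4-methylphenyl now has a direct reading at this position, para to a large group: a 1.1-fold higher number from compound 3 to compound 4 (0.06 log units; within the scatter), so fluoro and methyl cannot be told apart here. With the 4-methylphenyl held constant, the other outer ring also gives no readable difference, with a 1.1-fold higher number from compound 2 to compound 4 (0.05 log units; within the scatter) for fluoro in place of methyl and a 1.0-fold higher number from compound 1 to compound 4 (0.01 log units; within the scatter) for fluoro in place of chloro. No measurement beyond these cell numbers is available to interpret the result.

The compounds shown span only fluoro, chloro and methyl on the two outer rings, so it remains open whether an amine, a carboxylic acid or a longer chain at either place would give a step beyond the scatter. As far as these compounds go, the unsubstituted phenyl shared by all four compounds also remains open, as a methoxy group or a chloro group on that ring has no reading here.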